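Mirror-Image Lactone: Expecting the Enantiomer's Cytotoxicity

The source may hold more compounds than are shown below. What is called first, only, known or untested is meant among the compounds shown, and "the series" means these compounds.

Measured so far:
compound 1, `CCCCC[C@H](CCC[C@@H]1CC=CC(=O)O1)OC`: 20500 nM
compound 2, `CCCCC[C@@H](C[C@H](O)C[C@@H]1CC=CC(=O)O1)OC`: 26300 nM

The study concerns a small set of unsaturated lactones tested in a functional assay on A2780 ADR cells (Homo sapiens) for cytotoxicity, read by MTT assay, with a stated time of 24 h; a lower number here means a stronger inhibitor, a higher number a weaker inhibitor. Compound 1 `CCCCC[C@H](CCC[C@@H]1CC=CC(=O)O1)OC` gives 20500 nM in this assay. Compound 2 `CCCCC[C@@H](C[C@H](O)C[C@@H]1CC=CC(=O)O1)OC` gives 26300 nM in this assay, and its number and that of compound 1 lie within the usual scatter of each other, so the two are not distinguished by these data.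

Compound 3 `CCCCC[C@H](C[C@@H](O)C[C@H]1CC=CC(=O)O1)OC` is the mirror image of compound 2: the two compounds have the same atoms and bonds and differ only in configuration as drawn: 3 of 3 stereo elements differ (all stereocentres are inverted: mirror images); a stereocentre at a saturated chain carbon is drawn S in compound 2 and R in compound 3; a stereocentre at a saturated chain carbon is drawn S in compound 2 and R in compound 3; a stereocentre at a saturated ring carbon is drawn S in compound 2 and R in compound 3. Going by the values given here, no measured pair in this set reports the effect of inverting every stereocentre, so there is no step to lean on. Without such a step, the plain expectation is that compound 3 stays near compound 2, with a 1.1-fold lower number from compound 2 to compound 3 (0.02 log units; within the scatter) expected to fall within the scatter, though a real divergence between enantiomers cannot be excluded. Compound 3 is accordingly estimated at 25000 nM in this assay, with a range from 8000 nM to 80000 nM.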

Compound 3, half-maximal inhibitory concentration: 18100 nM
Compound 3: the middle estimate sits 1.4-fold (0.14 log units) above what was measured; low and high end bracket the measured number.
By their numbers in this assay, from the lowest: compounds 3, 1 and 2 (each within the scatter of the next).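

In this assay, going by these compounds alone, inverting all three stereocentres at once gives a 1.5-fold lower number from compound 2 to compound 3 (0.16 log units; within the scatter), the first measured mirror-image comparison in this set, and it does not tell the two enantiomers apart. Inverting the two stereocentres at saturated chain carbons together with the one at the saturated ring carbon leaves the read-out within the scatter. The comparison isolates a single kind of change: the fact that compounds 2 and 3 differ only in the configuration as drawn.

The compounds shown leave open what inverting any one of these stereocentres alone would do, as all three change together in this pair. They also leave open whether an amine or a carboxylic acid in place of the hydroxyl group would separate a mirror-image pair in this assay.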